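Working notes on an antiproliferative series and one successor

A few compounds are considered here, and "the series" means these few. Any claim that something is new, unique, unknown or untested is made for them only; others in the source may bear on it.

compound 1 `CC(C)(C)c1ccc(C2C(C#N)=C(N)OC3=C2C(=O)CC3)cc1`: 103 ug/mL
compound 2 `N#Cc1ccc(C(c2c(O)c3ccccc3oc2=O)c2c(O)c3ccccc3oc2=O)cc1`: 47.6 ug/mL

In a functional assay on HuTu80 cells (Homo sapiens) for antiproliferative activity, read by MTT assay, with a stated time of 48 h (a higher number here means a weaker inhibitor, a lower number a stronger inhibitor), compound 1 gives 103 ug/mL and compound 2 gives 47.6 ug/mL, the lower of the two numbers; the gap between compound 1 and compound 2 is beyond the scatter, so compound 2 is the stronger of the pair. Compound 3 `O=c1oc2ccccc2c(O)c1C(c1ccc(F)c(F)c1)c1c(O)c2ccccc2oc1=O` is not yet measured. It differs from compound 2 as 3,4-difluorophenyl in place of 4-cyanophenyl on a saturated chain carbon bound to two aromatic carbons. Within the data shown here, no measured pair shows this change, so no step beyond the scatter is expected. The step from compound 2 to compound 3 is estimated at a 1.1-fold lower number from compound 2 to compound 3 (0.02 log units; within the scatter). In this assay compound 3 is expected to give 45 ug/mL, within a range from 20 ug/mL to 110 ug/mL.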

Compound 3, half-maximal inhibitory concentration: 15 ug/mL
Compound 3: the middle estimate sits 3.0-fold (0.48 log units) above what was measured; measured number outside the range, below it.
By their numbers in this assay, from the lowest: compound 3; then compound 2; then compound 1.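

In this assay, among these compounds, the swap to 3,4-difluorophenyl in place of 4-cyanophenyl on a saturated chain carbon bound to two aromatic carbons gives a 3.2-fold lower number from compound 2 to compound 3 (0.50 log units; beyond the scatter) and is the first step read at this position, showing that the aryl group there affects the result. The change removes the nitrile and adds two fluorine atoms, and nothing at hand bears on why the number falls.

Still open, as far as these compounds go, is whether 4-fluorophenyl would give the same step, which would separate the contribution of each fluorine. An amine or a carboxylic acid on that phenyl ring also remains untested in the compounds shown.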